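This account rests on a few compounds, and the source may have more. Where it says the series, first, only, none or still open, it means among the compounds named here.

Compound 2 `CC/C=C\C/C=C\C/C=C\CCCCCCCc1cc(=O)c2c(O)cc(OCOC)cc2o1` and compound 1 `CCCC/C=C\CCCCCCCCCc1cc(=O)c2c(O)cc(OCOC)cc2o1` share a core and differ only in their side chain. In a functional assay on MDA-MB-231 cells (Homo sapiens) for antiproliferative activity, read by MTT assay (a lower number here means a stronger inhibitor, a higher number a weaker inhibitor), compound 2 gives 6790 nM. For compound 1 the reading in this assay is only a limit, > 87000 nM. For the measured compounds named here, the change between them is a group of 8 heavy atoms (8 carbon; no ring) in place of a group of 10 heavy atoms (10 carbon; no ring), on a saturated chain carbon, seven bonds along the chain from an aromatic carbon, and it brings an at least 12-fold higher number from compound 2 to compound 1 (1.10 log units; beyond the scatter); the only support for that reading is the limit of > 87000 nM in this assay, at which 1 of the 3 values shown sits. Compound 3 `CC/C=C\C/C=C\C/C=C\CCCCCCCc1cc(=O)c2c(O)c(C)c(O)c(C)c2o1` carries the longer chain of compound 2 on a different core; the difference between the two cores is not broken down here. In this assay compound 3 gives 6790 nM, level with compound 2. Compound 4 `CCCC/C=C\CCCCCCCCCc1cc(=O)c2c(O)c(C)c(O)c(C)c2o1` has not been measured; it bears the core of compound 3 and differs from it by a group of 8 heavy atoms (8 carbon; no ring) in place of a group of 10 heavy atoms (10 carbon; no ring), on a saturated chain carbon, seven bonds along the chain from an aromatic carbon, the same kind of change that separates compound 2 from compound 1. Given that the same chain change already moved compound 2 to compound 1 by an at least 12-fold higher number from compound 2 to compound 1 (1.10 log units; beyond the scatter), compound 4 is expected to be a weaker inhibitor than compound 3, estimated at 90000 nM in this assay, with a likely range from 30000 nM to 250000 nM. That estimate corresponds to an expected step of a 13-fold higher number from compound 3 to compound 4 (1.12 log units; beyond the scatter).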

Compound 4, half-maximal inhibitory concentration: > 87000 nM
Compound 4 ended at the assay's limit; the forecaster's own chance of this, stated with the estimate: 65%; the middle value lies beyond the limit too.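

Carried to the other core, the change to oct-3-en-1-yl brings an at least 12-fold higher number from compound 3 to compound 4 (1.10 log units; beyond the scatter) in this assay, the same direction as on the core of compound 2. Each of the two steps rests on a limit of the assay and not on a number, so their sizes cannot be set against each other: the same change on two cores in this assay, an at least 12-fold higher number (1.10 log units; beyond the scatter) from compound 2 to compound 1 and an at least 12-fold higher number (1.10 log units; beyond the scatter) from compound 3 to compound 4; the limit leaves it open whether they differ The two cores thus show the change carrying over in direction, but they do not show that it carries over in size, nor where the true values of the two shorter-chain compounds lie: the limit of > 87000 nM in this assay, at which 2 of the 4 values shown sit.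

The compounds shown leave open whether chain length or the double bonds matter more, as the two change together in this swap. Going by these compounds, a saturated decyl chain or a shorter hexyl chain on either core would bear on that question, and an amine or a carboxylic acid on the chain remains equally open.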